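Opening the Piperidine Ring at the Sulfonyl End

This account rests on a few compounds, and the source may have more. Where it says the series, first, only, none or still open, it means among the compounds named here.

All three measured compounds were tested in an assay on HEK293 cells for displacement of a labelled ligand from growth hormone secretagogue receptor type 1 (Homo sapiens), with a stated time of 60 min; a lower number here means a stronger inhibitor, a higher number a weaker inhibitor:
compound 1, `Cc1ccnn1-c1ccc(Cl)c(C(=O)NC(=O)Nc2nc3ccc(S(=O)(=O)C4CCN(C)CC4)cc3s2)c1`: 33 nM
compound 2, `CN1CCC(S(=O)(=O)c2ccc3nc(NC(=O)NC(=O)c4cc5c(cc4Cl)CCN5C)sc3c2)CC1`: 7.2 nM
compound 3, `CN1CCC(S(=O)(=O)c2ccc3nc(NC(=O)NC(=O)c4cc(-n5cccn5)ccc4Cl)sc3c2)CC1`: 15 nM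

Compound 3 stands second highest of the three numbers in this assay. Its nearest neighbour is compound 2, reached through a 2.1-fold higher number from compound 2 to compound 3 (0.32 log units; beyond the scatter), a modest step beyond the scatter; its furthest is compound 1, through a 2.2-fold lower number from compound 1 to compound 3 (0.34 log units; beyond the scatter), also modest and beyond the scatter. Both steps change only the acyl side of the shared core.

Compound 4, `CCN(CC)CCCS(=O)(=O)c1ccc2nc(NC(=O)NC(=O)c3cc(-n4cccn4)ccc3Cl)sc2c1`, differs from compound 3 at the other end of the molecule: 3-(diethylamino)propyl in place of 1-methylpiperidin-4-yl on a sulfonyl sulfur. Within the data shown here, no measured step touches this sulfonyl substituent, so the two measured steps give no direct guide; they only show that single changes elsewhere on this core moved the number by modest amounts. With the chain replacing the ring at a position otherwise untested, the expectation is a step within the scatter or at most modest, with no clear direction, which is written as a 1.3-fold higher number from compound 3 to compound 4 (0.12 log units; within the scatter). Compound 4 is therefore estimated at 20 nM in this assay, within a range of 6 nM to 70 nM.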

Compound 4, half-maximal inhibitory concentration: 3.9 nM
For compound 4 the middle estimate is 5.1-fold (0.71 log units) above the measured one; the measured number lies below the stated range.
By their numbers in this assay, from the lowest: compounds 4 and 2 (each within the scatter of the next); then compound 3; then compound 1.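

The sulfonyl end of the molecule proves to be a place where the result can change: in this assay, replacing the ring with the chain gives a 3.8-fold lower number from compound 3 to compound 4 (0.59 log units; beyond the scatter), so compound 4 is the stronger inhibitor of this pair. With the rest of the molecule held fixed, the 1-methylpiperidin-4-yl ring is therefore not needed to keep binding at this level, since the ringless 3-(diethylamino)propyl group gives a lower number, though the step is still only modest. Both groups have the same counts of hydrogen-bond donors and acceptors and each has one nitrogen, but no measurement here explains why the chain does better.

This single step changes several things at once, including the ring, the groups on the nitrogen and the overall size, so the compounds shown cannot tell which of these matters; a 3-(dimethylamino)propyl or a 2-(diethylamino)ethyl group on the sulfonyl sulfur would begin to separate them. Going by these compounds, it also remains open whether the 3-(diethylamino)propyl group would lower the number to a similar extent when paired with the acyl groups of compound 1 or compound 2.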